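The compounds below may be only part of what the source reports. "The series", "measured", "known", "first", "only" and "open" are said of these compounds alone.

Measured so far:
Compound 1 `O=C(/C=C/c1cccnc1)NCCCCc1ccc(S(=O)(=O)Nc2ccccc2)cc1` — 17.8 nM
Compound 2 `Cc1ccc(NS(=O)(=O)c2cccc(CCCCCCNC(=O)/C=C/c3cccnc3)c2)cc1` — 9.78 nM

Both compounds were tested in an assay on isolated protein for inhibition of Nicotinamide phosphoribosyltransferase (Homo sapiens), read by WST assay, with stated times of 60 min, 5 min and 30 min, in the presence of a further agent that is not named here; on this read-out lower numbers stand for stronger inhibition and higher numbers for weaker inhibition. On the two numbers shown, compound 2 sits at the low end, and its only neighbour is compound 1, whose number lies within the usual scatter of compound 2, so the two cannot be told apart and neither can be called the stronger inhibitor.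

Compound 3 `O=C(/C=C/c1cccnc1)NCCCCCCc1cccc(S(=O)(=O)Nc2ccc(F)cc2)c1` has not yet been measured. It keeps the whole core of compound 2 and differs in one spot: fluoro in place of methyl on an aromatic carbon. The group that leaves and the group that enters each count a single heavy atom, both sit on an aromatic carbon of a six-membered aromatic ring of carbon only, para to a large group, and neither changes the count of hydrogen-bond donors or acceptors. For the measured compounds named here, no measured pair in this set shows such a swap, so there is no step to lean on. The expected step, a 1.1-fold higher number from compound 2 to compound 3 (0.05 log units; within the scatter), is estimated to stay within the scatter, in no particular direction. Compound 3 is therefore expected to give 11 nM, with a range from 4 nM to 30 nM.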

Compound 3, half-maximal inhibitory concentration: 9.2 nM
Compound 3: middle estimate off by 1.2-fold (0.08 log units), on the high side; measured number inside the range.
By their numbers in this assay, from the lowest: compounds 3, 2 and 1 (each within the scatter of the next).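

In this assay, fluoro in place of methyl on an aromatic carbon para to a large group gives a 1.1-fold lower number from compound 2 to compound 3 (0.03 log units; within the scatter) and so leaves compound 2 and compound 3 indistinguishable. For the compounds shown here, compounds 1 and 2 differ in more than one place, so this pair gives the first reading of a single change in the set: at this position, a methyl and a fluoro are interchangeable in this assay, with neither giving a number that can be told apart from the other. No independent measurement is available to explain why the two groups give such similar numbers.

Going by these compounds, whether a chloro, a methoxy, a trifluoromethyl, an amine or a carboxylic acid on this same carbon would also stay within the scatter remains open, since a methyl and a fluoro are both single-atom groups with no hydrogen-bond donors or acceptors. Also open, on these data alone, is what the chain and the place of the sulfamoyl group each contribute, as compound 1 differs from compound 2 in several places at once, and a shorter or longer chain on the core of compound 3 would be a single change that could separate them.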